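Swapping the Five-Membered Ring on the Shared Core

A few compounds are considered here, and "the series" means these few. Any claim that something is new, unique, unknown or untested is made for them only; others in the source may bear on it.

Of the compounds shown here, three that share a common core have been measured in a functional assay with Alpha-1A adrenergic receptor (Homo sapiens) as the target, read by calcium flux; a lower number here means a smaller maximal response, a higher number a larger maximal response. Compound 1 `Cn1nccc1-c1ccccc1NCC1=NCCN1` gives 108%. Compound 2 `CCn1cc(-c2ccccc2NCC2=NCCN2)cn1` gives 0%. Compound 3 `Cc1n[nH]c(-c2ccccc2NCC2=NCCN2)n1` gives 87%, which places it second highest of the three numbers: its nearest neighbour is compound 1, and the gap a number 21 percentage points lower from compound 1 to compound 3 (beyond the scatter) lies beyond the scatter, while compound 2 sits far below it.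

Compound 4 `Cn1cc(-c2ccccc2NCC2=NCCN2)cn1` has not yet been measured in this assay. It differs from compound 3 in one place: 1-methyl-1H-pyrazol-4-yl in place of 3-methyl-1H-1,2,4-triazol-5-yl on an aromatic carbon.

Among the measured compounds shown here, only one measured step exchanges the five-membered ring on the core, the modest one from compound 1 to compound 3, and that step kept the response high. For the measured compounds named here, compound 4, however, carries a 1-methyl-1H-pyrazol-4-yl group, and the closest measured relative with a pyrazol-4-yl group is compound 2, whose response was 0%; no measured step links compound 2 and compound 4, so only the two values themselves can be compared. Given the very low number of compound 2, a large drop is expected, estimated as a number 67 percentage points lower from compound 3 to compound 4 (beyond the scatter). Compound 4 is therefore expected to give about 20%, within a range from 0% to 60%.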

Compound 4, largest response reached (reported as maximal response), in percent of the reference or control that the assay uses: 39%
Compound 4: the middle estimate sits 19 percentage points below what was measured, and the stated range covers the measured number.
By their numbers in this assay, from the lowest: compound 2; then compound 4; then compound 3; then compound 1.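

In this assay, the position at which the methylpyrazole joins the aromatic carbon matters a great deal: 1-methyl-1H-pyrazol-4-yl in place of 1-methyl-1H-pyrazol-5-yl gives a number 69 percentage points lower from compound 1 to compound 4 (beyond the scatter), so the same kind of ring can give quite different responses depending on how it is attached. The pyrazol-4-yl attachment does not by itself remove the response, however, since shortening the ethyl group on the ring nitrogen to a methyl gives a number 39 percentage points higher from compound 2 to compound 4 (beyond the scatter), showing that a small change on the far side of this ring also counts. Exchanging the 3-methyl-1H-1,2,4-triazol-5-yl group for 1-methyl-1H-pyrazol-4-yl gives a number 48 percentage points lower from compound 3 to compound 4 (beyond the scatter), so not every five-membered aromatic ring at this place sustains a high response, as the earlier step of a number 21 percentage points lower from compound 1 to compound 3 (beyond the scatter) alone might have suggested.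

Nothing available accounts for any of these differences in response. The compounds shown leave open how the response would run with a propyl chain or a plain hydrogen on the ring nitrogen of the pyrazol-4-yl group, and whether an amine on that ring would be tolerated.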